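What Fluoro May Do to Compound 3

The compounds below may be only part of what the source reports. "The series", "measured", "known", "first", "only" and "open" are said of these compounds alone.

compound 1 `Nc1ccc2oc(-c3cccc(F)c3)cc(=O)c2c1`: 269000 nM
compound 2 `CC(=O)Nc1ccc2oc(-c3ccccc3)c(O)c(=O)c2c1`: 64700 nM
compound 3 `Nc1ccc2oc(-c3ccccc3)c(O)c(=O)c2c1`: 217000 nM

In an ADME assay on MT4 cells (Homo sapiens) for cytotoxicity, read by MTT assay, with a stated time of 4 days (a higher number here means that more compound is tolerated, a lower number that less compound is tolerated), compound 3 gives 217000 nM, within the scatter of compound 1 and higher than compound 2. The next compound, compound 4 `Nc1ccc2oc(-c3cccc(F)c3)c(O)c(=O)c2c1`, differs from compound 3 by fluoro in place of hydrogen on an aromatic carbon. For the measured compounds named here, the only measured step is a 3.4-fold higher number from compound 2 to compound 3 (0.53 log units; beyond the scatter), and it concerns acetyl on a nitrogen, not fluoro, so it says little here. Going by the values given here, no measured step isolates fluoro. Compound 1 does carry fluoro, and its 269000 nM sits within the scatter of compound 3. No change beyond the scatter is therefore expected, and the estimated step is a 1.1-fold higher number from compound 3 to compound 4 (0.03 log units; within the scatter). For compound 4 the expected value is 230000 nM, with an estimated range from 110000 nM to 450000 nM.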

Compound 4, half-maximal cytotoxic concentration: 35300 nM
The estimate for compound 4 lay 6.5-fold (0.81 log units) above the measured number, outside the stated range (below it).
By their numbers in this assay, from the lowest: compounds 4 and 2 (each within the scatter of the next); then compounds 3 and 1 (each within the scatter of the next).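

In this assay fluoro in place of hydrogen on an aromatic carbon, meta to a large group, gives a 6.1-fold lower number from compound 3 to compound 4 (0.79 log units; beyond the scatter) so a single added atom at this position is enough to move the number beyond the scatter. Adding hydroxy to the core gives a 7.6-fold lower number from compound 1 to compound 4 (0.88 log units; beyond the scatter) so, with fluoro present, this change also lowers the number beyond the scatter. No measurement here bears on why the number falls.

On these data alone, whether chloro, methoxy or an amine at this position would lower the number as well stays open. So does what fluoro does to the core without hydroxy.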